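Replacing the aryl group of compound 3

The source may hold more compounds than are shown below. What is called first, only, known or untested is meant among the compounds shown, and "the series" means these compounds.

In a functional assay (aorta) with Oryctolagus cuniculus as the target (on this read-out lower numbers stand for tighter binding and higher numbers for weaker binding), compound 1 (`COc1cc(C(C)=O)ccc1OCCCN1CCC(C(c2ccc(F)cc2F)c2ccc(F)cc2F)CC1`) gives 15.9 nM, compound 2 (`COc1cc(C(C)=O)ccc1OCCCN1CCC(=C(c2ccc(F)cc2)c2ccc(F)cc2)CC1`) gives 3.98 nM and compound 3 (`COC(=O)c1ccc(OCCCN2CCC(C(c3ccc(F)cc3)c3ccc(F)cc3)CC2)c(OC)c1`) gives 1.26 nM. Compound 3 thus holds the lowest number of the three, and its gaps to both others lie beyond the scatter. Compound 4 (`N#Cc1ccc(OCCCN2CCC(C(c3ccc(F)cc3)c3ccc(F)cc3)CC2)cc1`) carries 4-cyanophenyl in place of 2-methoxy-4-(methoxycarbonyl)phenyl on an oxygen on a saturated carbon. Among the compounds with values here, no pair of measured compounds isolates this change, so the forecast is loose. Compound 3 already sits at the low end at 1.26 nM, which makes a rise the likelier direction. A moderate step toward weaker binding in this assay is expected, a 4.0-fold higher number from compound 3 to compound 4 (0.60 log units; beyond the scatter). Compound 4 is estimated at 5 nM, with an expected range of 1.3 nM to 20 nM.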

Compound 4, dissociation constant: 5.01 nM
Compound 4: middle estimate off by 1.0-fold (0.00 log units), on the low side; measured number inside the range.
By their numbers in this assay, from the lowest: compound 3; then compounds 2 and 4 (each within the scatter of the next); then compound 1.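

The place on an oxygen on a saturated carbon proves responsive in this assay: 4-cyanophenyl in place of 2-methoxy-4-(methoxycarbonyl)phenyl gives a 4.0-fold higher number from compound 3 to compound 4 (0.60 log units; beyond the scatter) as a modest step. The change removes both the methoxy and the methoxycarbonyl together, so the step belongs to the pair and not to either one. No measured evidence accounts for this step. Going by these compounds, what remains open is how each of those two groups contributes alone, and how a plain phenyl, or a phenyl bearing a carboxylic acid or an amide, would read here.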